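The source may report more compounds than this note shows. Statements on the series, on what has been measured and on what is new or still open speak of the compounds shown alone.

Measured compounds and their values:

- compound 1, `ClCc1cccc(Cn2cnc3ncnc(Cl)c32)c1`, gives 18200 nM
- compound 2, `ClCc1ccccc1Cn1cnc2ncnc(Cl)c21`, gives 2290 nM
- compound 3, `ClCc1cccc(Cn2cnc3nc(Cl)nc(Cl)c32)c1`, gives 1410 nM

All three were tested in a functional assay on Hs-578T cells (Homo sapiens) for cytotoxicity, read by sulforhodamine B assay, with a stated time of 48 h; a lower number here means a stronger inhibitor of growth, a higher number a weaker inhibitor of growth. Compound 3 differs from compound 1 in one place only: chloro in place of hydrogen on an aromatic carbon. That single change produced a 13-fold lower number from compound 1 to compound 3 (1.11 log units; beyond the scatter). Compound 2 is built from the same atoms as compound 1, joined differently; the difference between the two cores is not broken down here. In this assay compound 1 gives 18200 nM while compound 2 gives 2290 nM, a gap beyond the usual scatter. Compound 2 and compound 3, on the other hand, lie within the scatter of each other, so no order between them can be claimed.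

Compound 4, `ClCc1ccccc1Cn1cnc2nc(Cl)nc(Cl)c21`, has not yet been measured. Within the data shown here, it differs from compound 2 by chloro in place of hydrogen on an aromatic carbon, and this is the same change as the one from compound 1 to compound 3, described in identical terms for the place it occupies. The expected step from compound 2 to compound 4 is a 5.7-fold lower number from compound 2 to compound 4 (0.76 log units; beyond the scatter), somewhat smaller than the earlier instance, because that instance, a 13-fold lower number from compound 1 to compound 3 (1.11 log units; beyond the scatter), is a single observation and compound 2 already sits at a lower number than compound 1. Compound 4 is therefore estimated at 400 nM, expected to fall between 120 nM and 1300 nM.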

Compound 4, concentration for 50% growth inhibition: 670 nM
Compound 4: middle estimate off by 1.7-fold (0.22 log units), on the low side; low and high end bracket the measured number.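

In this assay, chloro in place of hydrogen on the aromatic carbon between two ring nitrogen atoms again gives a lower number, with a 3.4-fold lower number from compound 2 to compound 4 (0.53 log units; beyond the scatter), so the direction of the change carries over from the core of compound 1 to the core of compound 2. Among these compounds, the size of the step does not carry over, and the two instances are clearly different: the same change on two cores in this assay, a 13-fold lower number (1.11 log units; beyond the scatter) from compound 1 to compound 3 and a 3.4-fold lower number (0.53 log units; beyond the scatter) from compound 2 to compound 4, 3.8-fold (0.58 log units) apart, beyond the scatter of two such steps These four compounds give only two instances of the change, so they cannot show what sets its size or whether the same direction would hold on a third core.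

At this ring carbon the compounds shown compare only hydrogen and chloro, which leaves open what an amine, a methoxy group or a longer chain would do there. On these data alone, all four compounds also keep the chloromethyl group and the chloro group on the same ring as the new one, so the effect of replacing either with a hydroxymethyl group or an amine remains open too.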